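The source may hold more compounds than are shown below. What is called first, only, known or untested is meant among the compounds shown, and "the series" means these compounds.

Among the measured compounds shown here, compound 2 `O=C(N/N=C/c1ccccc1O)c1cccc(S(=O)(=O)N2CCOCC2)c1` gives 12100 nM in a functional assay on SMMC-7721 cells (Homo sapiens) for antiproliferative activity, read by MTT assay, with a stated time of 72 h (on this read-out higher numbers stand for weaker inhibition and lower numbers for stronger inhibition), the only full number among the two values shown. Compound 1 `O=C(N/N=C/c1ccccn1)c1cccc(S(=O)(=O)N2CCOCC2)c1` reaches only a limit of this assay, > 100000 nM. The step of an at least 8.2-fold lower number from compound 1 to compound 2 (0.91 log units; beyond the scatter) is bounded by the limit of > 100000 nM in this assay, at which 1 of the 2 values shown sits. Compound 3 `CCN(CC)c1ccc(/C=N/NC(=O)c2cccc(S(=O)(=O)N3CCOCC3)c2)c(O)c1` differs from compound 2 by diethylamino in place of hydrogen on an aromatic carbon. For the measured compounds named here, the one measured step concerns the other ring and gives no guide to this position. Compound 3 is therefore expected to give 6000 nM, with a range from 1500 nM to 25000 nM. The estimate amounts to an expected 2.0-fold lower number from compound 2 to compound 3 (0.30 log units; within the scatter).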

Compound 3, half-maximal inhibitory concentration: 27100 nM
Beside the measured number, compound 3's estimate is 4.5-fold (0.65 log units) below it; measured number outside the range, above it.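

On the ring that carries the hydroxy group, diethylamino at this position gives no gain in this assay, but instead a 2.2-fold higher number from compound 2 to compound 3 (0.35 log units; beyond the scatter) and so a modest loss of inhibition. Among the compounds shown here, this is the first reading at this position, and it shows that the position takes a group of this size at a modest cost rather than a complete loss. Nothing measured here gives a reason for this step.

On these data alone, whether methoxy, a primary amine or pyrrolidine at this position would keep the inhibition of compound 2 stays open.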